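Replacing a bromophenyl amide with a fluoro-methoxyphenyl amide

The source may hold more compounds than are shown below. What is called first, only, known or untested is meant among the compounds shown, and "the series" means these compounds.

Compound 3 `O=C(Nc1cccc(-c2oc3cc(-c4ccc(F)cc4)ccc3c(=O)c2O)c1)c1ccc(Br)cc1` gives 13500 nM in a functional assay on A549 cells (Homo sapiens) for antiproliferative activity, read by CCK-8 assay, with a stated time of 72 h (on this read-out higher numbers stand for weaker inhibition and lower numbers for stronger inhibition), the highest of the three numbers measured. Compound 2 `Cc1ccc(C(=O)Nc2cccc(-c3oc4cc(-c5ccc(F)cc5)ccc4c(=O)c3O)c2)cc1` gives 6910 nM, and compound 1 `O=C(Nc1cccc(-c2oc3cc(-c4ccc(F)cc4)ccc3c(=O)c2O)c1)c1ccccc1F` gives 4410 nM. The step of a 3.1-fold higher number from compound 1 to compound 3 (0.49 log units; beyond the scatter) lies beyond the scatter, whereas a 2.0-fold higher number from compound 2 to compound 3 (0.29 log units; within the scatter) does not. Compound 4 `COc1ccc(C(=O)Nc2cccc(-c3oc4cc(-c5ccc(F)cc5)ccc4c(=O)c3O)c2)c(F)c1` differs from compound 3 in one place: 2-fluoro-4-methoxyphenyl in place of 4-bromophenyl on a carbonyl carbon. Both measured steps bear on this change, since compound 4 carries a fluorine on the entering ring as compound 1 does, while the bromine of compound 3 is gone. A step back toward a lower number is therefore expected, a 2.3-fold lower number from compound 3 to compound 4 (0.35 log units; beyond the scatter), though of modest size. Compound 4 is estimated to give 6000 nM in this assay, within a range from 3000 nM to 12000 nM.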

Compound 4, half-maximal inhibitory concentration: 40000 nM
Compound 4: middle estimate off by 6.7-fold (0.82 log units), on the low side, outside the stated range (above it).
By their numbers in this assay, from the lowest: compounds 1, 2 and 3 (each within the scatter of the next, the first and the last beyond it); then compound 4.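

Adding methoxy to the 2-fluorophenyl ring gives a 9.1-fold higher number from compound 1 to compound 4 (0.96 log units; beyond the scatter), so the fluorine shared by these two compounds does not keep the number low once methoxy is present. The 2-fluoro-4-methoxyphenyl amide also stands apart from the other two amides, with a 5.8-fold higher number from compound 2 to compound 4 (0.76 log units; beyond the scatter) and a 3.0-fold higher number from compound 3 to compound 4 (0.47 log units; beyond the scatter), making compound 4 the weakest of the four in this assay. No evidence here accounts for this rise. From the compounds shown here alone, it remains open whether methoxy alone, without the fluorine, would give as high a number, and whether a hydroxyl or an amine in its place would do the same.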